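Halogen Exchange on the Benzamide: Chloro to Bromo

The compounds below may be only part of what the source reports. "The series", "measured", "known", "first", "only" and "open" are said of these compounds alone.

Two compounds have so far been tested in a functional assay on SMMC-7721 cells (Homo sapiens) for antiproliferative activity, read by MTT assay, with a stated time of 72 h; on this read-out higher numbers stand for weaker inhibition and lower numbers for stronger inhibition:

compound 1 `CN(C(=O)c1ccc(F)cc1)c1ccc2[nH]c(-c3n[nH]c4ccccc34)cc2n1` gives 9150 nM
compound 2 `CN(C(=O)c1ccc(Cl)cc1)c1ccc2[nH]c(-c3n[nH]c4ccccc34)cc2n1` gives 2420 nM

Compound 2 holds the lowest of the two numbers in this assay. Among the compounds with values here, the only measured step, a 3.8-fold lower number from compound 1 to compound 2 (0.58 log units; beyond the scatter), is the one separating it from compound 1, and it lies beyond the scatter, so the difference is real though modest.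

Compound 3 `CN(C(=O)c1ccc(Br)cc1)c1ccc2[nH]c(-c3n[nH]c4ccccc34)cc2n1` differs from compound 2 by bromo in place of chloro on an aromatic carbon, the exchange sitting on an aromatic carbon of a six-membered aromatic ring of carbon only. Within the data shown here, the one measured step bears directly on this change: it too was an exchange of one halogen for the next heavier one at the same carbon, and it moved the number down by a modest amount. Repeating the pattern once more would suggest a further drop, but with a single step as the whole basis a smaller movement, or one within the scatter, is equally plausible.

Compound 3 is therefore expected to give about 1500 nM in this assay, within a range of 600 nM to 4000 nM. The expected step is a 1.6-fold lower number from compound 2 to compound 3 (0.21 log units; within the scatter).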

Compound 3, half-maximal inhibitory concentration: 3460 nM
For compound 3 the middle estimate is 2.3-fold (0.36 log units) below the measured one; low and high end bracket the measured number.
By their numbers in this assay, from the lowest: compounds 2 and 3 (each within the scatter of the next); then compound 1.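

In this assay, replacing chloro with bromo at this position, para to a large group, leaves the two compounds within the usual scatter of each other (a 1.4-fold higher number from compound 2 to compound 3 (0.16 log units; within the scatter)). The drop in the number seen when chloro replaced fluoro therefore does not continue as a steady trend with each heavier halogen, and these three compounds instead fall into two levels. Bromo also remains clearly apart from fluoro (a 2.6-fold lower number from compound 1 to compound 3 (0.42 log units; beyond the scatter)), so compound 1 is the weakest of the three, while compound 2 and compound 3 cannot be ranked against each other, and no supporting data bear on why the chloro and bromo compounds sit so close.

On these data alone, all three compounds carry a single halogen at this carbon, so it remains open whether the level shared by chloro and bromo is specific to halogens or could also be reached with a methyl, a methoxy, a nitrile or an amine. The compounds shown also leave open how a hydrogen at this carbon would compare, and whether the same halogen order would hold if the rest of the molecule changed.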